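Hydrazone aryl variation on the shared urea core

The source may report more compounds than this note shows. Statements on the series, on what has been measured and on what is new or still open speak of the compounds shown alone.

Measured compounds in a functional assay on A549 cells (Homo sapiens) for cytotoxicity, read by MTT assay, with a stated time of 72 h; on this read-out lower numbers stand for stronger inhibition and higher numbers for weaker inhibition:
Compound 1 `CN(C)CCn1cnnc1-c1cc(Oc2ccc(NC(=O)N/N=C/c3cccc(O)c3)cc2F)ccn1` gives > 100000 nM, a limit of the assay rather than a number (the limit of > 100000 nM in this assay, at which 1 of the 3 values shown sits).
Compound 2 `CN(C)CCn1cnnc1-c1cc(Oc2ccc(NC(=O)N/N=C/c3ccc(F)cc3Cl)cc2F)ccn1` gives 1120 nM.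
Compound 3 `CN(C)CCn1cnnc1-c1cc(Oc2ccc(NC(=O)N/N=C/c3ccc(Cl)cc3)cc2F)ccn1` gives 780 nM.

Compound 3 and compound 2 sit within the scatter of each other, as a 1.4-fold lower number from compound 2 to compound 3 (0.16 log units; within the scatter) shows; compound 1 supplies only a limit. Compound 4 `CN(C)CCn1cnnc1-c1cc(Oc2ccc(NC(=O)N/N=C/c3c[nH]c4ccccc34)cc2F)ccn1` differs from compound 3 by 1H-indol-3-yl in place of 4-chlorophenyl on a carbon with a double bond to nitrogen. Within the data shown here, the only steps that bear on it are an at least 120-fold lower number from compound 1 to compound 3 (2.10 log units; beyond the scatter) and an at least 89-fold lower number from compound 1 to compound 2 (1.95 log units; beyond the scatter), both large, and both move from the one aryl group carrying a hydrogen-bond donor to a halogenated phenyl. Among the measured compounds shown here, no measured step installs an indolyl group, so the change is unanchored. A moderate rise in number is expected, a 2.6-fold higher number from compound 3 to compound 4 (0.41 log units; beyond the scatter), with wide uncertainty. Compound 4 is estimated at 2000 nM, between 300 nM and 20000 nM.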

Compound 4, half-maximal inhibitory concentration: 820 nM
The estimate for compound 4 lay 2.4-fold (0.39 log units) above the measured number; low and high end bracket the measured number.
By their numbers in this assay, from the lowest: compounds 3, 4 and 2 (each within the scatter of the next). At a limit, above all of these: compound 1.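

In this assay the 1H-indol-3-yl group on the carbon with a double bond to nitrogen cannot be told apart from either halogenated phenyl group (a 1.1-fold higher number from compound 3 to compound 4 (0.02 log units; within the scatter); a 1.4-fold lower number from compound 2 to compound 4 (0.14 log units; within the scatter)). A hydrogen-bond donor on the aryl group therefore does not by itself bring the loss of activity at this position (an at least 120-fold lower number from compound 1 to compound 4 (2.08 log units; beyond the scatter)). That step is only a bound, as compound 1 stands at a limit of the assay: the limit of > 100000 nM in this assay, at which 1 of the 4 values shown sits.

Still open, from the compounds shown here alone, is whether the drop belongs to 3-hydroxyphenyl alone. Aryl groups carrying an amine or a carboxylic acid at this carbon could settle that.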